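Compound 3 to compound 4: one group changes

This account rests on a few compounds, and the source may have more. Where it says the series, first, only, none or still open, it means among the compounds named here.

compound 1 `N#Cc1cnc(NCc2cnccc2C(F)(F)F)cc1N[C@H]1C[C@H](O)C1` gives 96%
compound 2 `N#Cc1cnc(NCc2cnccc2C(F)(F)F)cc1N[C@H]1CC[C@@H](c2nc[nH]n2)CC1` gives 13%
compound 3 `CC(C)(F)c1ncncc1CNc1cc(N[C@H]2CC[C@@H](O)CC2)c(C#N)cn1` gives 89%

In an ADME assay on S9 fraction from liver (Homo sapiens) for metabolic stability, with a stated time of 1 h (a lower number here means that less of the compound is left, a higher number that more of the compound is left), compound 3 gives 89% and stands within the usual scatter of compound 1 with 96% on the same read-out. Compound 2 gives 13% which lies lower than compound 3 by far more than the scatter.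

Compound 4 `CC(C)(C)Oc1ncncc1CNc1cc(N[C@H]2CC[C@@H](O)CC2)c(C#N)cn1` has not been measured yet. It keeps everything in compound 3 except one group: tert-butoxy in place of 1-fluoro-1-methylethyl on an aromatic carbon in a six-membered aromatic ring with 2 nitrogen, next to the ring nitrogen.

Among the compounds with values here, no two measured compounds differ in this group alone, so the data show no direct precedent for the size of this change. Compound 3 already has 89% left after the incubation, so there is little room upward and much more downward. A moderate fall is therefore expected, and the estimated step is a number 13 percentage points lower from compound 3 to compound 4 (beyond the scatter) with a wide margin. Compound 4 is expected to give 76% (estimated range 50% to 93%).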

Compound 4, percent of the compound remaining: 54%
Beside the measured number, compound 4's estimate is 22 percentage points above it; the range from low to high includes it.
By their numbers in this assay, from the lowest: compound 2; then compound 4; then compounds 3 and 1 (each within the scatter of the next).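

Within the data shown here, this is the first pair here that differs in one place, and it shows that the group on this aromatic carbon, next to the ring nitrogen, matters in this assay: tert-butoxy in place of 1-fluoro-1-methylethyl gives a number 35 percentage points lower from compound 3 to compound 4 (beyond the scatter), with the rest of the molecule unchanged. On paper the swap is small, with 5 heavy atoms and 1 hydrogen-bond acceptor entering where 4 heavy atoms and 0 hydrogen-bond acceptors leave, yet that edit alone moves the number well past ordinary scatter. Nothing measured here speaks to why the number moves.

A single step at this position cannot separate the effect of the oxygen link from the effect of the bulk of the whole group, and a methoxy group, an isopropyl group or an amine on the same carbon would help pull those two apart. On these data alone, whether a step of this size would also appear with a different group elsewhere on the molecule remains open as well.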